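The compounds below may be only part of what the source reports. "The series", "measured", "known", "first", "only" and "open" are said of these compounds alone.

Measured compounds:
Compound 1 `COc1cc(C(c2ccc(O)c(OC)c2)[C@@H](C)[C@H](C)CO)ccc1O`: in a functional assay on HeLa cells (Homo sapiens) for cytotoxicity, read by WST assay, with a stated time of 48 h (on this read-out lower numbers stand for stronger inhibition and higher numbers for weaker inhibition), compound 1 reaches only a limit, > 100000 nM.
Compound 2 `CCCCC[C@H](C(C)C)C(c1ccc(O)c(OC)c1)c1ccc(O)c(OC)c1`: compound 2 gives 9200 nM.
Compound 3 `COC[C@H](C(C)C)C(c1ccc(O)c(OC)c1)c1ccc(O)c(OC)c1`: compound 3 gives 76000 nM.

Compound 2 holds the lowest of the two numbers shown; compound 3 stands nearest, with an 8.3-fold higher number from compound 2 to compound 3 (0.92 log units; beyond the scatter). Compound 4 `COc1cc(C(c2ccc(O)c(OC)c2)[C@@H](C)[C@H](C)CF)ccc1O` differs from compound 2 in one place: 2-(fluoromethyl)-1-methylpropyl in place of 1-isopropylhexyl on a saturated chain carbon bound to two aromatic carbons. Compound 4 thus carries 2-(fluoromethyl)-1-methylpropyl where compound 1 carries 2-(hydroxymethyl)-1-methylpropyl, so the step of an at least 10-fold lower number from compound 1 to compound 2 (1.03 log units; beyond the scatter) bears most on it; the limit of > 100000 nM in this assay, at which 1 of the 3 values shown sits, covers compound 1. Reversing that large step is expected to raise the number markedly, and a 6.5-fold higher number from compound 2 to compound 4 (0.81 log units; beyond the scatter) is the expected outcome, with the new value possibly reaching a limit again. Compound 4 is therefore estimated at 60000 nM, ranging from 15000 nM to 200000 nM.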

Compound 4, half-maximal inhibitory concentration: 37000 nM
The estimate for compound 4 lay 1.6-fold (0.21 log units) above the measured number; the measured number falls inside the stated range.
By their numbers in this assay, from the lowest: compound 2; then compound 4; then compound 3. At a limit, above all of these: compound 1.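

Fluoro in place of hydroxy on the short chain gives an at least 2.7-fold lower number from compound 1 to compound 4 (0.43 log units; beyond the scatter) in this assay, and that size is only a floor, since the starting value is a limit. So the end of this short chain alone can shift the read-out, and the fluoro chain also shows a 2.1-fold lower number from compound 3 to compound 4 (0.31 log units; beyond the scatter). The longer 1-isopropylhexyl group still keeps the lowest number, with a 4.0-fold higher number from compound 2 to compound 4 (0.60 log units; beyond the scatter).

On these data alone, whether an amine or a carboxylic acid at that chain end would lower or raise the number remains open. So does whether a fluoro group on a longer chain would add to the effect of length.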